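This account rests on a few compounds, and the source may have more. Where it says the series, first, only, none or still open, it means among the compounds named here.

Compound 2 `CC(=O)OC[C@H]1O[C@@H](n2cc(CN3C(=O)/C(=C\C=C\c4ccccc4)c4ccccc43)nn2)[C@H](OC(C)=O)[C@@H](OC(C)=O)[C@@H]1OC(C)=O` stands at the high end of the two numbers recorded so far: in a functional assay on A549 cells (Homo sapiens) for cytotoxicity, read by sulforhodamine B assay, with a stated time of 48 h (on this read-out lower numbers stand for stronger inhibition and higher numbers for weaker inhibition), compound 2 gives 58400 nM, while compound 1 `CC(=O)OC[C@H]1O[C@@H](n2cc(CN3C(=O)/C(=C/c4ccccc4)c4ccccc43)nn2)[C@H](OC(C)=O)[C@@H](OC(C)=O)[C@@H]1OC(C)=O` gives 20600 nM in this assay. Compound 3 `CC(=O)OC[C@H]1O[C@@H](n2cc(CN3C(=O)/C(=C/C=C/c4ccccc4)c4ccccc43)nn2)[C@H](OC(C)=O)[C@@H](OC(C)=O)[C@@H]1OC(C)=O` has not yet been measured. the two compounds have the same atoms and bonds and differ only in configuration as drawn: 1 of 7 stereo elements differ; a double bond is drawn Z in compound 2 and E in compound 3 The two compounds have the same atoms and bonds and differ only in configuration as drawn. Going by the values given here, no measured pair here separates a Z-drawn from an E-drawn double bond, so there is no step to lean on. The step from compound 2 to compound 3 is estimated as a 1.3-fold lower number from compound 2 to compound 3 (0.11 log units; within the scatter), which he expects to be small and without a clear direction, quite possibly within the scatter. Compound 3 is accordingly expected to give about 45000 nM in this assay, with the likely range running from 15000 nM to 150000 nM.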

Compound 3, half-maximal inhibitory concentration: > 100000 nM
Compound 3: only a limit was reported; the forecaster's own chance of this, stated with the estimate: 10%; at least 2.2-fold (0.34 log units) between middle value and limit.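

In this assay compound 3 gives > 100000 nM, which is a limit of the assay and not a number. The change of double-bond configuration as drawn gives an at least 1.7-fold higher number from compound 2 to compound 3 (0.23 log units; that floor lies within the scatter), so this floor alone does not establish a real difference between the two isomers: the fact that compounds 2 and 3 differ only in the configuration as drawn. Going by these compounds alone, with 2-phenylethenyl in place of phenyl on a double-bonded chain carbon bound to a double-bonded ring carbon, the data give an at least 4.8-fold higher number from compound 1 to compound 3 (0.68 log units; beyond the scatter), the first step at this position that clears the scatter and one showing that this longer group, as drawn in compound 3, costs activity.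

On these data alone, the true value of compound 3 stays open, and with it the full size of both steps. Also open, as far as these compounds go, is how this position responds when an amine or a carboxylic acid takes the place of the phenyl.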